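The source may report more compounds than this note shows. Statements on the series, on what has been measured and on what is new or still open speak of the compounds shown alone.

In a functional assay on HCT-116 cells (Homo sapiens) for antiproliferative activity, read by MTT assay, with a stated time of 72 h (a lower number here means a stronger inhibitor, a higher number a weaker inhibitor), compound 1 `NC1=NC2(CCOCC2)N(OCCCOc2ccccc2Cl)C(N)=N1` gives 70 nM, while compound 2 `NC1=NC2(CCOCC2)N(OCCCOc2ccccc2Br)C(N)=N1` gives 30 nM, the lower of the two numbers. Compound 3 `NC1=NC2(CCOCC2)N(OCCCOc2cccc(Br)c2)C(N)=N1` has 3-bromophenyl in place of 2-bromophenyl on an oxygen on a saturated carbon. Among the compounds with values here, the only measured step, a 2.3-fold lower number from compound 1 to compound 2 (0.37 log units; beyond the scatter), exchanges chloro for bromo rather than moving a group, so it bears on this change only loosely. A step of similar modest size towards a higher number is therefore expected in this assay, namely a 2.0-fold higher number from compound 2 to compound 3 (0.30 log units; within the scatter). The estimate for compound 3 is 60 nM, with an expected range of 20 nM to 200 nM.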

Compound 3, half-maximal inhibitory concentration: 40 nM
Compound 3: middle estimate off by 1.5-fold (0.18 log units), on the high side, and the stated range covers the measured number.
By their numbers in this assay, from the lowest: compounds 2, 3 and 1 (each within the scatter of the next, the first and the last beyond it).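

In this assay, 3-bromophenyl in place of 2-bromophenyl on an oxygen on a saturated carbon gives a 1.3-fold higher number from compound 2 to compound 3 (0.12 log units; within the scatter), so this read-out does not separate these two bromophenyl groups. 3-Bromophenyl in place of 2-chlorophenyl gives a 1.8-fold lower number from compound 1 to compound 3 (0.24 log units; within the scatter), so this change also stays within the scatter, unlike the exchange of chloro for bromo that gave a 2.3-fold lower number from compound 1 to compound 2 (0.37 log units; beyond the scatter). Nothing available explains these results. The compounds shown leave open how an amine or a carboxylic acid in place of bromo on the phenyl ring would read in this assay, and how a longer chain would read.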